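One Aryl Swap on a Shared Receptor-Binding Core

A few compounds are considered here, and "the series" means these few. Any claim that something is new, unique, unknown or untested is made for them only; others in the source may bear on it.

Of the compounds shown here, two built on the same core have been measured in an in vitro assay on HEK293 cells for displacement of a labelled ligand from adenosine receptor A2b (Homo sapiens); on this read-out lower numbers stand for stronger inhibition and higher numbers for weaker inhibition. Compound 1 `CCCn1c(=O)c2nc(-c3ccnn3-c3ccccc3)[nH]c2n(CCC)c1=O` gives 1100 nM in this assay. Compound 2 `CCCn1c(=O)c2nc(-c3cnn(Cc4cccc(C)c4)c3)[nH]c2n(CCC)c1=O` gives 36 nM in this assay, the lowest of the two numbers, with compound 1 sitting at a higher number by a gap beyond the usual scatter.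

Compound 3 `CCCn1c(=O)c2nc(-c3cnn(Cc4ccc(F)c(C(F)(F)F)c4)c3)[nH]c2n(CCC)c1=O` has not yet been measured. It differs from compound 2 in one place: 4-fluoro-3-(trifluoromethyl)phenyl in place of 3-methylphenyl on a saturated chain carbon bound to an aromatic nitrogen. Among the compounds with values here, no measured pair spans this position, so the only guidance is that compound 2 already sits far below compound 1, and that the change keeps a six-membered aromatic ring of carbon only on a saturated chain carbon bound to an aromatic nitrogen.

In this assay compound 3 is expected to give 50 nM, with a range from 15 nM to 170 nM. The step of a 1.4-fold higher number from compound 2 to compound 3 (0.14 log units; within the scatter) is expected to be small, probably within the usual scatter, in either direction.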

Compound 3, inhibition constant: 640 nM
Compound 3: middle estimate off by 13-fold (1.11 log units), on the low side; measured number outside the range, above it.
By their numbers in this assay, from the lowest: compound 2; then compounds 3 and 1 (each within the scatter of the next).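

In this assay, the group on the saturated chain carbon bound to an aromatic nitrogen proves far from interchangeable: 4-fluoro-3-(trifluoromethyl)phenyl in place of 3-methylphenyl gives an 18-fold higher number from compound 2 to compound 3 (1.25 log units; beyond the scatter). This is a large step, even though both groups hold one six-membered aromatic ring of carbon only and neither has a hydrogen-bond donor or acceptor, so what the ring carries matters at this position. No available measurement gives a reason for the size of this step.

The compounds shown leave open whether the fluorine, the trifluoromethyl or only the two together account for the higher number, as a ring carrying just one of them would tell. Also open, on these data alone, is how a ring bearing a chlorine or a methoxy group would read here.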